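The compounds below may be only part of what the source reports. "The series", "measured", "known", "first", "only" and "open" are said of these compounds alone.

Values so far in a functional assay on HL-60 cells (Homo sapiens) for cytotoxicity, read by MTT assay, with a stated time of 72 h (a lower number here means a stronger inhibitor, a higher number a weaker inhibitor), for the series:
compound 1 `COC(=O)c1sc2nc(C)ccc2c1Nc1cc(OC)c(OC)c(OC)c1` gives 0.4 nM
compound 2 `COC(=O)c1sc2ncccc2c1Nc1cc(OC)c(OC)c(OC)c1` gives 2920 nM
compound 3 `CCOC(=O)c1sc2cc(C)ccc2c1Nc1cc(OC)c(OC)c(OC)c1` gives 3.9 nM
Not yet measured: compound 4 `CCOC(=O)c1sc2ncccc2c1Nc1cc(OC)c(OC)c(OC)c1`

Compound 2 holds the highest of the three numbers, and its gaps to compound 1 and compound 3 both lie beyond the scatter. The change to compound 4 is methyl in place of hydrogen on a saturated chain carbon bound to an oxygen next to a carbonyl group and amounts to methoxycarbonyl to ethoxycarbonyl.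

Among the measured compounds shown here, no measured step covers this change directly. For the measured compounds named here, the only measured step is a 7300-fold higher number from compound 1 to compound 2 (3.86 log units; beyond the scatter) and it belongs to a methyl on an aromatic carbon, a different place. That step is large, but its size does not carry over. Compound 3 carries ethoxycarbonyl and gives 3.9 nM in this assay but has a different core from compound 4, so it shows only that an ethyl ester can coexist with a low number.

No step beyond the scatter is expected in this assay and no direction is favoured with confidence. The expected result is a 1.2-fold lower number from compound 2 to compound 4 (0.07 log units; within the scatter) in this estimate. Compound 4 is estimated at 2500 nM with an expected range of 500 nM to 8000 nM for its measurement.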

Compound 4, half-maximal inhibitory concentration: 6100 nM
The estimate for compound 4 lay 2.4-fold (0.39 log units) below the measured number; the measured number falls inside the stated range.
By their numbers in this assay, from the lowest: compound 1; then compound 3; then compound 2; then compound 4.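

In this assay, among the compounds shown here, extending methoxycarbonyl to ethoxycarbonyl gives a 2.1-fold higher number from compound 2 to compound 4 (0.32 log units; beyond the scatter), the first direct reading of this position. The step is modest and lies beyond the scatter, so the added methyl on the saturated chain carbon bound to an oxygen next to a carbonyl group has a measurable effect, but one far smaller than a 7300-fold higher number from compound 1 to compound 2 (3.86 log units; beyond the scatter), which belongs to the methyl on an aromatic carbon. No supporting data bear on why the number moves at this position.

On these data alone, the change is read on the core of compound 2 only, so its size and direction on the core of compound 1 remain open. As far as these compounds go, how a longer chain such as a propyl ester, or a carboxylic acid or primary amide in place of the ester, would read at this position also remains open.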